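Ethyl in place of phenyl: compound 1 to compound 3

This account rests on a few compounds, and the source may have more. Where it says the series, first, only, none or still open, it means among the compounds named here.

In a physicochemical assay for metabolic stability, read by HPLC, at pH 4.5, tested at 10 uM (on this read-out higher numbers stand for a longer-lived compound and lower numbers for a shorter-lived compound), compound 1 `O=C(NCCCCc1ccccc1)N1C(=O)c2ccccc2C1=O` gives > 2 h, which is a limit of the assay and not a number. Compound 2 `O=C(NCCCCc1ccccc1)n1cnc2ccccc21` gives > 2 h, again a limit. Compound 1 therefore stands at the limit of > 2 h in this assay, at which 2 of the 2 values shown sit, so its true position is not known.

Compound 3 `CCCCCCNC(=O)N1C(=O)c2ccccc2C1=O` changes one place of compound 1: ethyl in place of phenyl on a saturated chain carbon, four bonds along the chain from an amide-type nitrogen, with ethyl in place of phenyl on a saturated chain carbon, four bonds along the chain from an amide-type nitrogen.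

For the measured compounds named here, no measured pair shows the size of such a change in this assay. The expectation is therefore no step beyond the scatter, with the direction left open. The expected step that the limit leaves unreadable from compound 1 to compound 3 is only a working figure. The half-life estimated for compound 3 is 4 h, with an expected range of 2 h to 10 h.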

Compound 3, half-life: > 2 h
Compound 3 ended at the assay's limit; the forecaster's own chance of this, stated with the estimate: 75%; the middle value does not contradict the limit.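

For the compounds shown here, no step from compound 1 to compound 3 can be read, since both stand at a limit and not at a number: the limit of > 2 h in this assay, at which 3 of the 3 values shown sit.

The compounds shown leave open how long any of them actually lasts, and whether ethyl in place of phenyl changes the half-life at all.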